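From Carboxy to Ethoxycarbonyl on a Weakly Active Compound

The source may hold more compounds than are shown below. What is called first, only, known or untested is meant among the compounds shown, and "the series" means these compounds.

Going by the values given here, only two compounds have been measured so far, and both read weakly. In a functional assay on JeKo-1 cells (Homo sapiens) for inhibition, read by luminescence and CellTiter-Glo, with a stated time of 72 h (a higher number here means a weaker inhibitor, a lower number a stronger inhibitor), compound 1 (`C/C=C/C(=O)N1CCCC(n2nc(-c3ccc(Oc4ccccc4)cc3)cc2C(=O)OCC)C1`) gives 26500 nM as its half-maximal inhibitory concentration.

Compound 2 (`C=CC(=O)N1CCCC(n2nc(-c3ccc(Oc4ccccc4)cc3)cc2C(=O)O)C1`) has no number in this assay and is recorded only as the limit > 60000 nM of that assay. It therefore stands at the limit and cannot be placed exactly.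

Compound 3 (`C=CC(=O)N1CCCC(n2nc(-c3ccc(Oc4ccccc4)cc3)cc2C(=O)OCC)C1`) changes compound 2 in one place, and the change is ethyl in place of hydrogen on an oxygen next to a carbonyl group on an oxygen next to a carbonyl group, so that carboxy becomes ethoxycarbonyl.

Among the compounds with values here, no measured step shows what this change does. Within the data shown here, the only guide is compound 1, which also carries ethoxycarbonyl and reads 26500 nM in this assay as a measurable number. On that basis, a moderate move toward stronger inhibition is expected, and the estimated at least 3.0-fold lower number from compound 2 to compound 3 (0.47 log units; beyond the scatter) is uncertain since it starts from a limit.

Compound 3 is expected to stay a weak inhibitor, with an estimated value of 20000 nM in a range from 6000 nM to 60000 nM when measured.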

Compound 3, half-maximal inhibitory concentration: 21200 nM
Compound 3: the middle estimate sits 1.1-fold (0.03 log units) below what was measured; measured number inside the range.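

Going by these compounds alone, for the first time a step at this position can be read in this assay: ethyl in place of hydrogen on an oxygen next to a carbonyl group, which turns carboxy into ethoxycarbonyl, gives an at least 2.8-fold lower number from compound 2 to compound 3 (0.45 log units; beyond the scatter). The starting point of that step, compound 2, is a limit of the assay and not a number: the limit of > 60000 nM in this assay, at which 1 of the 3 values shown sits. The second step, vinyl in place of prop-1-en-1-yl on a carbonyl carbon, gives a 1.3-fold lower number from compound 1 to compound 3 (0.10 log units; within the scatter), so with ethoxycarbonyl present the two compounds cannot be told apart in this assay, and both remain weak inhibitors.

The compounds shown leave open whether this step belongs to ethyl in particular, or whether methyl, a longer chain such as butyl, or an amine in place of the ethoxy group would read the same. They also leave open whether carboxy behaves the same way with prop-1-en-1-yl on the carbonyl carbon, and whether any replacement at this position could move compound 3 far from its 21200 nM.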